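Toward the unsubstituted benzamide in a urotensin-2 receptor series

The source may hold more compounds than are shown below. What is called first, only, known or untested is meant among the compounds shown, and "the series" means these compounds.

Compound 1, `Cc1ccccc1C(=O)NC(CCN(C)C)c1ccc(Cl)cc1`: 3550 nM
Compound 2, `COc1ccc(C(=O)NC(CCN(C)C)c2ccc(Cl)cc2)cc1`: 1350 nM
Compound 3, `Cc1cccc(Cl)c1C(=O)NC(CCN(C)C)c1ccc(Cl)cc1`: 5130 nM

All three compounds were tested in an assay on NIH3T3 cells with Urotensin-2 receptor (Homo sapiens) as the target; on this read-out lower numbers stand for an effect already at smaller amounts and higher numbers for an effect only at larger amounts of compound. Compound 3 stands at the highest number of the three; its nearest neighbour is compound 1 with a 1.4-fold higher number from compound 1 to compound 3 (0.16 log units; within the scatter), and its furthest is compound 2 with a 3.8-fold higher number from compound 2 to compound 3 (0.58 log units; beyond the scatter).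

Compound 4, `CN(C)CCC(NC(=O)c1ccccc1)c1ccc(Cl)cc1`, is the next member of the series. Compared with compound 3 the change is phenyl in place of 2-chloro-6-methylphenyl on a carbonyl carbon. Two of the measured steps bear on this change. The first, a 1.4-fold higher number from compound 1 to compound 3 (0.16 log units; within the scatter), shows that adding a chloro to the aromatic ring on the carbonyl carbon moved the number only within the scatter. The second, a 2.6-fold lower number from compound 1 to compound 2 (0.42 log units; beyond the scatter), shows a modest shift when the substituent pattern on that ring was altered more broadly. Taken together, stripping both the chloro and the methyl from compound 3 is expected to give a small to modest decrease in the number, though the case where it stays within the scatter cannot be excluded.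

For compound 4 the expected step is a 1.6-fold lower number from compound 3 to compound 4 (0.20 log units; within the scatter). On that basis compound 4 is estimated at 3200 nM, with a range from 1100 nM to 9500 nM.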

Compound 4, half-maximal effective concentration: 1410 nM
Estimate against measurement, compound 4: 2.3-fold (0.36 log units) above; low and high end bracket the measured number.
By their numbers in this assay, from the lowest: compounds 2 and 4 (each within the scatter of the next); then compounds 1 and 3 (each within the scatter of the next).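

Among the compounds shown here, the step from the substituted ring to plain phenyl turns out larger than the earlier steps suggested: a 3.6-fold lower number from compound 3 to compound 4 (0.56 log units; beyond the scatter) in this assay, whereas adding the chloro alone gave only a 1.4-fold higher number from compound 1 to compound 3 (0.16 log units; within the scatter). Hydrogen in place of methyl accounts for a shift beyond the scatter on its own, with a 2.5-fold lower number from compound 1 to compound 4 (0.40 log units; beyond the scatter), so the methyl is the substituent whose loss can be read on this ring. Hydrogen in place of methoxy, by contrast, gives a 1.0-fold higher number from compound 2 to compound 4 (0.02 log units; within the scatter), so plain phenyl and 4-methoxyphenyl stand level, and among these four compounds the two higher numbers belong to the two that carry a methyl on the ring, with no compound going against this. The data shown offer no independent measurement that would explain these differences.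

On these data alone, it stays open whether an ethyl or a fluoro in place of the methyl would give the same rise as the methyl does. Equally open, as far as these compounds go, is whether a hydroxyl or an amine on the phenyl ring could bring the number below the level shared by compound 2 and compound 4.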